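The compounds below may be only part of what the source reports. "The series", "measured", "known", "first", "only" and "open" are said of these compounds alone.

Measured compounds:
- compound 1, `O=C(O)CC/C=C\CO[C@H]1[C@@H](OCc2ccc(-c3ccccc3CO)cc2)CC[C@@H]1N1CCCCCC1`: 12.6 nM
- compound 2, `O=C(O)CC/C=C\CO[C@@H]1[C@@H](OCc2ccc(-c3ccccc3)cc2)CC[C@@H]1N1CCCCC1`: 1000 nM
- compound 3, `O=C(O)CC/C=C\CO[C@H]1C(OCc2ccc(-c3ccccc3CO)cc2)CC[C@@H]1N1CCCCCC1`: 6.31 nM

In a functional assay for antagonist activity at thromboxane A2 receptor (Rattus norvegicus) (a lower number here means tighter binding, a higher number weaker binding), compound 1 gives 12.6 nM, the second highest of the three numbers. Its nearest neighbour is compound 3, and the step of a 2.0-fold lower number from compound 1 to compound 3 (0.30 log units; within the scatter) lies within the scatter; the only point of difference there is a stereocentre drawn with a configuration in one and without one in the other (the fact that one of compounds 1 and 3 is drawn with a defined configuration and the other without, at the place where they differ). Compound 2 stands much further away, at 1000 nM.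

Compound 4, `O=C(O)CC/C=C\CO[C@H]1[C@@H](OCc2ccc(-c3ccccc3)cc2)CC[C@@H]1N1CCCCCC1`, differs from compound 1 by hydrogen in place of hydroxymethyl on an aromatic carbon. Going by the values given here, none of the measured steps touches this position, since the one measured step concerns a stereocentre rather than the hydroxymethyl group, so there is no direct precedent for the size or direction of the change. Compound 4 is therefore expected to shift by a 4.0-fold higher number from compound 1 to compound 4 (0.60 log units; beyond the scatter), with wide uncertainty. Compound 4 is estimated at 50 nM, within a range from 10 nM to 250 nM.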

Compound 4, dissociation constant: 39.8 nM
Compound 4: middle estimate off by 1.3-fold (0.10 log units), on the high side; low and high end bracket the measured number.
By their numbers in this assay, from the lowest: compounds 3 and 1 (each within the scatter of the next); then compound 4; then compound 2.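

Going by these compounds alone, this is the first measured step at this position: in this assay, replacing hydroxymethyl with hydrogen gives a 3.2-fold higher number from compound 1 to compound 4 (0.50 log units; beyond the scatter). The direction shows that, on this core, the 2-(hydroxymethyl)phenyl group goes with the lower number, yet the change is modest, and without the hydroxymethyl group compound 4 still gives 39.8 nM. Nothing in the information available accounts for this step.

As far as these compounds go, whether a different group on this aromatic carbon, such as a methoxy group, an amine, a carboxylic acid or a longer chain like hydroxyethyl, would match or exceed hydroxymethyl remains open. Also open, from the compounds shown here alone, is whether the step would keep its size on the core of compound 2.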